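Swapping the pyridine substituent on compound 1

The source may report more compounds than this note shows. Statements on the series, on what has been measured and on what is new or still open speak of the compounds shown alone.

Compound 1 `O=C(O)Cc1sc(C(c2ccc(F)cc2)c2ccc(F)cc2)nc1-c1cc(F)nc(F)c1` stands highest of the two numbers recorded so far: in an in vitro functional assay on HEK285-7 cells for antagonist activity at prostaglandin D2 receptor 2 (Homo sapiens), read by BRET and beta-arrestin recruitment (a lower number here means a smaller maximal response, a higher number a larger maximal response), compound 1 reaches 80%. Compound 2 `O=C(O)Cc1sc(C(c2ccccc2)c2ccccn2)nc1-c1ccc(Cl)cc1` is the nearest, and in this assay compound 2 gives 55%, a gap beyond the usual scatter. Compound 3 `CN(C)c1cc(-c2nc(C(c3ccc(F)cc3)c3ccc(F)cc3)sc2CC(=O)O)ccn1` differs from compound 1 in one place: 2-(dimethylamino)pyridin-4-yl in place of 2,6-difluoropyridin-4-yl on an aromatic carbon. No step of this kind has been measured among the compounds shown, so the direction is uncertain; a small change, within the scatter or slightly downward, is expected, a number 8 percentage points lower from compound 1 to compound 3 (within the scatter). Compound 3 is therefore estimated at 72%, between 45% and 95%.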

Compound 3, largest response reached (reported as efficacy), in percent of the reference or control that the assay uses: 80%
Compound 3: the middle estimate sits 8 percentage points below what was measured, within the range that was stated.
By their numbers in this assay, from the lowest: compound 2; then compounds 1 and 3 (each within the scatter of the next).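

In this assay, 2-(dimethylamino)pyridin-4-yl in place of 2,6-difluoropyridin-4-yl gives no change at the digits printed from compound 1 to compound 3 (within the scatter) on this aromatic carbon next to the ring nitrogen. Within the data shown here, this is the first step read at this position, and it shows that the maximal response tolerates the exchange of both fluorines for a single dimethylamino group. Nothing available explains this outcome. As far as these compounds go, whether a morpholine or a methoxy group on the pyridine would also leave the response in place remains open. So does whether this step would hold with a different group in place of the two 4-fluorophenyl rings.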